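This account rests on a few compounds, and the source may have more. Where it says the series, first, only, none or still open, it means among the compounds named here.

Of the compounds shown here, three of a shared core have been measured in a functional assay on ileum for inhibition of histamine H1 receptor (Cavia porcellus); a higher number here means a weaker inhibitor, a lower number a stronger inhibitor. Compound 1 `CC(C)CCn1c(N2CCN(C)CC2)nc2ccccc21` gives 1400 nM, the highest of the three numbers. Compound 2 `CCCCCN1CCN(c2nc3ccccc3n2CCOCC)CC1` gives 30 nM, and compound 3 `CCCCOCCn1c(N2CCCN(C)CC2)nc2ccccc21` gives 10 nM; both values lie well below that of compound 1, yet compounds 2 and 3 differ from compound 1 in more than one place, so no single change can be read off from them.

Compound 4 `CCCCCCCCCCn1c(N2CCN(C)CC2)nc2ccccc21` has not yet been measured in this assay. It differs from compound 1 in one place: octyl in place of isopropyl on a saturated chain carbon, two bonds along the chain from an aromatic nitrogen. Within the data shown here, no measured pair here isolates a change of this kind. Since the two compounds with lower numbers, compound 2 and compound 3, both carry larger groups on the core, the step from compound 1 to compound 4 is expected to lower the number, but by an uncertain amount, so the step of a 4.7-fold lower number from compound 1 to compound 4 (0.67 log units; beyond the scatter) is expected to be moderate. Compound 4 is estimated at 300 nM, within a range of 60 nM to 1500 nM.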

Compound 4, half-maximal inhibitory concentration: 4200 nM
The estimate for compound 4 lay 14-fold (1.15 log units) below the measured number; measured number outside the range, above it.
By their numbers in this assay, from the lowest: compound 3; then compound 2; then compound 1; then compound 4.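

At this place, on a saturated chain carbon, two bonds along the chain from an aromatic nitrogen, octyl in place of isopropyl gives a 3.0-fold higher number from compound 1 to compound 4 (0.48 log units; beyond the scatter) in this assay. Among these compounds, this is the first single change that can be read here, and it shows that the longer carbon chain goes with a weaker inhibitor, not a stronger one. Nothing measured here gives a reason for this step.

A single step cannot show whether the number rises steadily with chain length or changes direction at an intermediate chain such as butyl. It also leaves open how a hydroxyl or an amine at the end of the chain would shift the number at this place.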